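The source may report more compounds than this note shows. Statements on the series, on what has been measured and on what is new or still open speak of the compounds shown alone.

Compound 1 `O=C(Nn1c(-c2cccc([N+](=O)[O-])c2)nc2c(-c3ccc(Cl)cc3)n[nH]c2c1=O)c1cccnc1`: 16.3%
Compound 2 `COc1cccc(-c2nc3c(-c4ccc(C5CCNCC5)cc4)n[nH]c3c(=O)n2NC(=O)c2ccncc2)c1`: 23.4%
Compound 3 `COc1cccc(-c2nc3c(-c4ccco4)n[nH]c3c(=O)n2NC(=O)c2cccnc2)c1`: 34.1%

Of the compounds shown here, three sharing the same fused core have been measured in a functional assay on SK-MEL-2 cells (Homo sapiens) for cytotoxicity, read by sulforhodamine B assay, with a stated time of 2 days, tested at 100 uM; on this read-out lower numbers stand for less inhibition and higher numbers for more inhibition at the one concentration tested (going by the name of the read-out). Compound 1 gives 16.3%, and this is the lowest of the three numbers. Compound 2 gives 23.4%, a number that lies within the usual scatter of the value for compound 1, so the two cannot be told apart. Compound 3 gives 34.1%, and here the gap to compound 1 lies beyond the scatter. Among the compounds with values here, compound 3 and compound 2 differ from compound 1 in more than one place, so no single step between measured compounds can be drawn.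

Compound 4 `O=C(Nn1c(-c2cccc([N+](=O)[O-])c2)nc2c(-c3cccs3)n[nH]c2c1=O)c1cccnc1` is the next compound, not yet measured. It differs from compound 1 in one place: thiophen-2-yl in place of 4-chlorophenyl on an aromatic carbon. Within the data shown here, nothing among the measured compounds isolates this change, so the expectation rests on the spread seen so far. The step from compound 1 to compound 4 is expected to be a number 5.7 percentage points higher from compound 1 to compound 4 (within the scatter), a small rise that is not expected to reach beyond the scatter. Compound 4 is therefore expected to give 22%, with a range from 8% to 40%.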

Compound 4, a percentage reported as inhibition, at one concentration (the size of the read-out at that concentration, not a potency): 3.26%
Estimate against measurement, compound 4: 18.7 percentage points above, outside the stated range (below it).
By their numbers in this assay, from the lowest: compound 4; then compounds 1 and 2 (each within the scatter of the next); then compound 3.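

In this assay, the aromatic carbon of the five-membered ring with two nitrogens is now the one place where a single change can be read, with the rest of the molecule unchanged. Thiophen-2-yl in place of 4-chlorophenyl gives a number 13 percentage points lower from compound 1 to compound 4 (beyond the scatter), so the number read here does depend on the group carried at this carbon, a dependence the earlier compounds could not isolate. No measurement at hand explains the drop.

This single step exchanges a six-membered carbon ring bearing chlorine for a five-membered ring with sulfur, so it cannot separate the loss of the chlorine from the change of ring. A plain phenyl ring or a small alkyl group such as methyl at this carbon would be needed to tell how far the trend extends.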